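The compounds below may be only part of what the source reports. "The series", "measured", "known", "first", "only" and "open" are said of these compounds alone.

Measured so far in this study:
compound 1, `c1ccc(COc2ccc(Nc3ncnc4cc5c(cc34)OCCOCCOCCO5)cc2)cc1`, 8340 nM
compound 2, `FC(F)(F)c1ccc(COc2ccc(Nc3ncnc4cc5c(cc34)OCCOCCOCCO5)cc2)cc1`, 28500 nM
compound 3, `c1ccc(COc2ccc(Nc3ncnc4cc5c(cc34)OCCOCCO5)cc2)cc1`, > 100000 nM

In a functional assay on MCF7 cells (Homo sapiens) for antiproliferative activity, read by MTT assay, with a stated time of 72 h (on this read-out higher numbers stand for weaker inhibition and lower numbers for stronger inhibition), compound 1 gives 8340 nM. Compound 2 differs from compound 1 by trifluoromethyl in place of hydrogen on an aromatic carbon. In this assay compound 2 gives 28500 nM, so the change brings a 3.4-fold higher number from compound 1 to compound 2 (0.53 log units; beyond the scatter); that is, adding the trifluoromethyl group made the inhibition weaker.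

Compound 3 is built on a different core from compound 1; the difference between the two cores is not broken down here. For compound 3 the reading in this assay is a limit of the assay and not a number: > 100000 nM. This is the limit of > 100000 nM in this assay, at which 1 of the 3 values shown sits.

Compound 4, `FC(F)(F)c1ccc(COc2ccc(Nc3ncnc4cc5c(cc34)OCCOCCO5)cc2)cc1`, has not yet been measured in this assay. It differs from compound 3 by trifluoromethyl in place of hydrogen on an aromatic carbon, the same change that was made from compound 1 to compound 2. The expectation rests on that earlier step: compound 2 moved to a higher number than compound 1 by a 3.4-fold higher number from compound 1 to compound 2 (0.53 log units; beyond the scatter), and the same move is expected here. Since compound 3 already sits at the limit, compound 4 is expected to give about 340000 nM, most likely again reported only as a limit. The range expected for compound 4 is from 100000 nM to 1500000 nM. In step terms the estimate for compound 4 means a step that the limit leaves unreadable from compound 3 to compound 4.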

Compound 4, half-maximal inhibitory concentration: > 100000 nM
Compound 4: only a limit was reported; the forecaster's own chance of this, stated with the estimate: 90%; the middle value does not contradict the limit.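

In this assay compound 4 gives > 100000 nM, which is a limit of the assay and not a number. Compound 3 and compound 4 both stand at this same limit, so no step between them can be read: the limit of > 100000 nM in this assay, at which 2 of the 4 values shown sit.

The compounds shown leave open whether trifluoromethyl in place of hydrogen weakens inhibition on the core of compound 3, as it did on the core of compound 1.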